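Loss of one methoxy group: measured and expected effects

The source may report more compounds than this note shows. Statements on the series, on what has been measured and on what is new or still open speak of the compounds shown alone.

Measured compounds, with values in a functional assay on Malme-3M cells (Homo sapiens) for inhibition, read by sulforhodamine B assay, with a stated time of 48 h; a lower number here means a stronger inhibitor of growth, a higher number a weaker inhibitor of growth:
compound 1 `COc1cc(-c2cc(/C=C/C(=O)c3ccc(N)cc3)[nH]n2)cc(OC)c1OC`: 4710 nM
compound 2 `COc1ccc(-c2cc(/C=C/C(=O)c3ccc(N)cc3)[nH]n2)cc1OC`: 21200 nM
compound 3 `COc1cc(C(=O)/C=C/c2cc(-c3cc(OC)c(OC)c(OC)c3)n[nH]2)cc(OC)c1OC`: 4090 nM

Compound 1 and compound 2 differ in one place, (hydrogen in place of methoxy on an aromatic carbon), and the step is a 4.5-fold higher number from compound 1 to compound 2 (0.65 log units; beyond the scatter). Compound 3 stands at the low end of the three numbers in this assay; its gap to compound 1 lies within the scatter, while compound 2 gives a number well beyond the scatter above it. How the core of compound 3 differs from the core of compound 1 is not broken down here.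

Compound 4 `COc1ccc(-c2cc(/C=C/C(=O)c3cc(OC)c(OC)c(OC)c3)[nH]n2)cc1OC` has not yet been measured in this assay. It differs from compound 3 by hydrogen in place of methoxy on an aromatic carbon, the same change that separates compound 1 from compound 2: the group that leaves, the group that enters and the surroundings of the place are the same word for word in both pairs. For the measured compounds named here, the one measured instance of this change weakened growth inhibition to a modest degree, so a step of about the same size is expected from compound 3 to compound 4, a 3.9-fold higher number from compound 3 to compound 4 (0.59 log units; beyond the scatter), because compound 1 to compound 2 gave a 4.5-fold higher number from compound 1 to compound 2 (0.65 log units; beyond the scatter). With a single precedent the expected range is kept wide. Compound 4 is thus estimated at 16000 nM in this assay, with a range from 6000 nM to 45000 nM.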

Compound 4, concentration for total growth inhibition: 6190 nM
Compound 4: middle estimate off by 2.6-fold (0.41 log units), on the high side; measured number inside the range.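

Working notes on the methoxy loss. In this assay, the loss of one methoxy group does not carry over at a constant size from one core to the other: the same change on two cores in this assay, a 4.5-fold higher number (0.65 log units; beyond the scatter) from compound 1 to compound 2 and a 1.5-fold higher number (0.18 log units; within the scatter) from compound 3 to compound 4, 3.0-fold (0.47 log units) apart, beyond the scatter of two such steps

On the core of compound 3 the step is a 1.5-fold higher number from compound 3 to compound 4 (0.18 log units; within the scatter), so this pair gives no measurable separation, whereas the pair on the core of compound 1 does; a size read from one core therefore cannot be transferred directly to the other in this series. For the compounds shown here, with only two pairs, the data show that the step differs between these two cores, but not which feature of the cores goes with the difference, nor what size the step would take on a third core.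

Open, going by these compounds, is whether a hydroxyl group, an ethoxy group or a chlorine atom at the same place, ortho to a methoxy group, would follow the pattern of the core of compound 1 or that of the core of compound 3. Also open, on these data alone, is how either core would respond to the loss of a further methoxy group from the same ring.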